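The source may hold more compounds than are shown below. What is called first, only, known or untested is meant among the compounds shown, and "the series" means these compounds.

Compound 3 `O=C(CCCCCCC(=O)Nc1cccc(C(F)(F)F)c1)NO` gives 75.1 nM in an assay on isolated protein for inhibition of histone deacetylase 11 (Homo sapiens), read by fluorescence; a lower number here means a stronger inhibitor, a higher number a weaker inhibitor. Among the three compounds measured so far, compound 3 stands second highest: compound 1 `O=C(CCCCC[C@H](NC(=O)[C@@H]1CCCC(=O)N1)C(=O)Nc1ccccc1)NO` gives 47 nM, a value within the scatter of compound 3, while compound 2 `O=C(CCCCCCC(=O)NC1CCCC1)NO` gives 2630 nM, well above compound 3 and beyond the scatter. Compound 4 `Cc1cccc(NC(=O)CCCCCCC(=O)NO)c1` differs from compound 3 by methyl in place of trifluoromethyl on an aromatic carbon. Within the data shown here, no measured pair shows this change directly, so its size can only be expected. Compound 4 keeps the aromatic amide of compound 3, which compound 2 lacks, so a modest weakening, about the size of the scatter, is expected in this assay: a 2.0-fold higher number from compound 3 to compound 4 (0.30 log units; within the scatter). Compound 4 is therefore estimated at 150 nM, with a range from 50 nM to 500 nM.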

Compound 4, half-maximal inhibitory concentration: 1600 nM
Compound 4: middle estimate off by 11-fold (1.03 log units), on the low side, outside the stated range (above it).
By their numbers in this assay, from the lowest: compounds 1 and 3 (each within the scatter of the next); then compounds 4 and 2 (each within the scatter of the next).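

In this assay, methyl in place of trifluoromethyl on this aromatic carbon proves a large change, with a 21-fold higher number from compound 3 to compound 4 (1.33 log units; beyond the scatter). Keeping the aromatic amide therefore does not by itself hold the number low: this one group moves it beyond the scatter. Nothing available gives a reason for the size of this step. The compounds shown leave open whether chlorine, a nitrile or a methoxy group on the same carbon would give a number nearer that of trifluoromethyl or of methyl. They also leave open whether trifluoromethyl elsewhere on the ring would do the same.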